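A few compounds are considered here, and "the series" means these few. Any claim that something is new, unique, unknown or untested is made for them only; others in the source may bear on it.

Measured in a functional assay on MCF7 cells (Homo sapiens) for antiproliferative activity, read by MTT assay, with a stated time of 72 h (on this read-out lower numbers stand for stronger inhibition and higher numbers for weaker inhibition), are two compounds:
- Compound 1 `CCOc1cccc(/C=N/NC(=O)c2cccc(S(=O)(=O)N3CCOCC3)c2)c1O` gives 19300 nM
- Compound 2 `O=C(N/N=C/c1cc(Cl)ccc1O)c1cccc(S(=O)(=O)N2CCOCC2)c1` gives 16500 nM

Compound 2 stands level with compound 1, as the two values lie within the scatter of each other. Compound 3 `O=C(N/N=C/c1cc(Br)ccc1O)c1cccc(S(=O)(=O)N2CCOCC2)c1` differs from compound 2 by bromo in place of chloro on an aromatic carbon and so carries bromo in place of chloro on an aromatic carbon. Within the data shown here, the one measured step that bears on this is a 1.2-fold lower number from compound 1 to compound 2 (0.07 log units; within the scatter) and it put 5-chloro-2-hydroxyphenyl in place of 3-ethoxy-2-hydroxyphenyl. Nothing beyond the scatter is therefore expected in this assay for this exchange. The expected step is a 1.1-fold lower number from compound 2 to compound 3 (0.04 log units; within the scatter) on this reading. Compound 3 is estimated at 15000 nM with a range of 7500 nM to 30000 nM on this read-out.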

Compound 3, half-maximal inhibitory concentration: 26600 nM
For compound 3 the middle estimate is 1.8-fold (0.25 log units) below the measured one, and the stated range covers the measured number.
By their numbers in this assay, from the lowest: compounds 2, 1 and 3 (each within the scatter of the next).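

Within this assay the exchange of chloro for bromo, para to a hydroxy group, brings a 1.6-fold higher number from compound 2 to compound 3 (0.21 log units; within the scatter) and so moves nothing beyond the scatter at this position. Against the 3-ethoxy-2-hydroxyphenyl of compound 1, the 5-bromo-2-hydroxyphenyl brings a 1.4-fold higher number from compound 1 to compound 3 (0.14 log units; within the scatter) and stands level too, so neither halogen sets itself apart. No evidence at hand speaks to why these values sit together.

On these data alone, whether this position can shift the number at all stays open, as all three compounds stand level. An amine or a carboxylic acid in place of the halogen would put that to the test.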